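A few compounds are considered here, and "the series" means these few. Any claim that something is new, unique, unknown or untested is made for them only; others in the source may bear on it.

Measured in a functional assay on HepG2 cells (Homo sapiens) for antiproliferative activity, read by CCK-8 assay, with a stated time of 48 h; on this read-out higher numbers stand for weaker inhibition and lower numbers for stronger inhibition:

Compound 1 (`COc1ccc(/C=C\c2cc(OC)c(OC)c(OC)c2)cc1OCc1ccc(C=O)cc1`) gives 800 nM
Compound 2 (`COc1ccc(/C=C\c2cc(OC)c(OC)c(OC)c2)cc1OCc1ccc(CN2CCCCC2C(=O)O)cc1`) gives 3100 nM
Compound 3 (`COc1ccc(/C=C\c2cc(OC)c(OC)c(OC)c2)cc1OCc1ccc(CN2CC(C(=O)O)C2)cc1`) gives only a limit, > 10000 nM

Among the measured compounds shown here, compound 3 is the one compound without a number, and it sits at the limit of > 10000 nM in this assay, at which 1 of the 3 values shown sits. The compound still unmeasured, compound 4 (`COc1ccc(/C=C\c2cc(OC)c(OC)c(OC)c2)cc1OCc1ccc(CN2CC[C@@H](O)C2)cc1`), differs from it in one place: 3-hydroxypyrrolidin-1-yl in place of 3-carboxyazetidin-1-yl on a saturated chain carbon bound to an aromatic carbon. In words, 3-hydroxypyrrolidin-1-yl stands in place of 3-carboxyazetidin-1-yl on a saturated chain carbon bound to an aromatic carbon.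

For the measured compounds named here, no measured step makes this exact exchange, but three steps concern the same place. They are a 3.9-fold higher number from compound 1 to compound 2 (0.59 log units; beyond the scatter), an at least 12-fold higher number from compound 1 to compound 3 (1.09 log units; beyond the scatter) and an at least 3.2-fold higher number from compound 2 to compound 3 (0.50 log units; beyond the scatter). The last of these shows that exchanging one ring group for another at this place can move the number by itself. Both carboxy-bearing compounds lie above compound 1 at 800 nM, and compound 4 no longer carries a carboxy group. A step to a lower number in this assay is therefore expected, of modest size or more, bringing compound 4 into the region of compound 2 at 3100 nM. The estimated change is an at least 3.3-fold lower number from compound 3 to compound 4 (0.52 log units; beyond the scatter). For compound 4 the expected value is 3000 nM, with an estimated range from 900 nM to 10000 nM.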

Compound 4, half-maximal inhibitory concentration: 6200 nM
Compound 4: the middle estimate sits 2.1-fold (0.32 log units) below what was measured; the measured number falls inside the stated range.
By their numbers in this assay, from the lowest: compound 1; then compounds 2 and 4 (each within the scatter of the next). At a limit, above all of these: compound 3.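

In this assay, compound 3 remains a limit and not a number: the limit of > 10000 nM in this assay, at which 1 of the 4 values shown sits. On these data alone, the exchange at this place can therefore be read only as a floor, an at least 1.6-fold lower number from compound 3 to compound 4 (0.20 log units; that floor lies within the scatter), and its true size stays unknown. What compound 4 adds is a group on the saturated chain carbon that carries a hydroxy group and no carboxy group, and this still leaves a clear distance from the formyl compound, a 7.8-fold higher number from compound 1 to compound 4 (0.89 log units; beyond the scatter), while it cannot be told apart from the 2-carboxypiperidin-1-yl compound, a 2.0-fold higher number from compound 2 to compound 4 (0.30 log units; within the scatter); among the compounds shown, then, the carboxy group alone does not separate the ring-bearing compounds from compound 1.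

The compounds shown do not separate ring size from the change of substituent, a question that 3-hydroxyazetidin-1-yl or 3-carboxypyrrolidin-1-yl at the same place would address directly. They also leave open whether the defined stereocentre of 3-hydroxypyrrolidin-1-yl matters, which its mirror-image form would test, and how an open-chain amine such as dimethylamino would compare.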